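Swapping cyano for acetamido on the shared core

The source may hold more compounds than are shown below. What is called first, only, known or untested is meant among the compounds shown, and "the series" means these compounds.

Measured so far in a functional assay (aorta) with Oryctolagus cuniculus as the target; a lower number here means tighter binding, a higher number weaker binding:
- Compound 1 `CC(=O)c1ccc(OCCCN2CCC(C(c3ccc(F)cc3)c3ccc(F)cc3)CC2)cc1`: 2.51 nM
- Compound 2 `N#Cc1ccc(OCCCN2CCC(C(c3ccc(F)cc3)c3ccc(F)cc3)CC2)cc1`: 5.01 nM

Compound 2 stands at 5.01 nM, within the scatter of compound 1, so the two cannot be told apart on these numbers. The next compound, compound 3 `CC(=O)Nc1ccc(OCCCN2CCC(C(c3ccc(F)cc3)c3ccc(F)cc3)CC2)cc1`, keeps the shared core and changes one group: acetamido in place of cyano on an aromatic carbon. Acetamido takes the place of cyano on an aromatic carbon, para to a large group.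

Going by the values given here, only one measured step bears on this place: a 2.0-fold higher number from compound 1 to compound 2 (0.30 log units; within the scatter). That step lies within the scatter, and it exchanged cyano for acetyl, not for acetamido. Among the compounds with values here, no measured compound carries an acetamido group, so the data give only weak guidance, and no direction can be drawn from them. No step beyond the scatter is therefore expected in this assay, though the uncertainty is wide. The estimate corresponds to an expected 1.2-fold higher number from compound 2 to compound 3 (0.08 log units; within the scatter). In this assay the expected value for compound 3 is 6 nM, with an estimated range from 1.5 nM to 24 nM.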

Compound 3, dissociation constant: 12.6 nM
Beside the measured number, compound 3's estimate is 2.1-fold (0.32 log units) below it; low and high end bracket the measured number.
By their numbers in this assay, from the lowest: compounds 1 and 2 (each within the scatter of the next); then compound 3.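

In this assay, the aromatic carbon para to a large group now shows a step beyond the scatter, which the exchange of acetyl for cyano had not shown. Acetamido in place of cyano gives a 2.5-fold higher number from compound 2 to compound 3 (0.40 log units; beyond the scatter), and acetamido in place of acetyl gives a 5.0-fold higher number from compound 1 to compound 3 (0.70 log units; beyond the scatter), so both earlier groups stand apart from acetamido in the same direction, although they cannot be told apart from each other. Acetamido differs from cyano in its count of heavy atoms and in carrying a hydrogen-bond donor, but nothing available ties the higher number to either difference or to any other feature of the group.

The three compounds leave open whether the amide hydrogen or the larger size of acetamido goes with the higher number, a question that a simple amine or an N-methylacetamido group at this place could help to address. They also leave open how a methoxy group, a carboxylic acid or a longer acyl chain on the amide nitrogen would stand in this assay on the shared core.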